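This account rests on a few compounds, and the source may have more. Where it says the series, first, only, none or still open, it means among the compounds named here.

Measured so far:
- compound 1, `Cc1nc(C)c([C@H](OC(C)(C)C)C(=O)O)c(N2CCC(C)(C)CC2)c1-c1ccc(CCCc2ccc(F)cc2)cc1`: in an ADME assay on microsomes from liver (Rattus norvegicus) for metabolic stability, read by LC-MS, tested at 0.5 uM (a higher number here means that the compound lasts longer, a lower number that the compound disappears faster), compound 1 gives > 2 h, which is a limit of the assay and not a number.
- compound 2, `Cc1ccc(CCOc2ccc(-c3c(C)nc(C)c([C@H](OC(C)(C)C)C(=O)O)c3N3CCC(C)(C)CC3)cc2)s1`: in this assay compound 2 gives > 2 h, likewise a limit and not a number.

The two share a core and differ in one place: the step from compound 1 to compound 2 is a step that the two limits leave unreadable from compound 1 to compound 2. Compound 2 therefore stands at the limit of > 2 h in this assay, at which 2 of the 2 values shown sit, and nothing finer than that limit is known about it.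

The next compound, compound 3, `Cc1nc(C)c([C@H](OC(C)(C)C)C(=O)O)c(N2CCC(C)(C)CC2)c1-c1ccc(OCCc2cccnc2)cc1`, is made from compound 2 by one change: pyridin-3-yl in place of 5-methylthiophen-2-yl on a saturated chain carbon, two bonds along the chain from an oxygen on an aromatic ring. Among the compounds with values here, no measured step bears on this change, since the only step in hand, from compound 1 to compound 2, concerns a different part of the chain and cannot be read. The expectation for compound 3 therefore rests on where compound 2 sits alone, and the step from compound 2 to compound 3 is estimated as a step that the limit leaves unreadable from compound 2 to compound 3, with no direction claimed beyond the scatter. On that basis compound 3 is expected to give about 2.5 h in this assay, within 1 h to 6 h.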

Compound 3, half-life: 0.783 h
Estimate against measurement, compound 3: 3.2-fold (0.50 log units) above, outside the stated range (below it).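

In this assay, pyridin-3-yl in place of 5-methylthiophen-2-yl on a saturated chain carbon, two bonds along the chain from an oxygen on an aromatic ring, gives an at least 2.5-fold lower number from compound 2 to compound 3 (0.40 log units; beyond the scatter). Likewise, 2-(pyridin-3-yl)ethoxy in place of 3-(4-fluorophenyl)propyl on an aromatic carbon gives an at least 2.5-fold lower number from compound 1 to compound 3 (0.40 log units; beyond the scatter), so these compounds offer the first readable sign that the group on this chain can change the half-life. Compound 1 and compound 2 each stand at a limit of the assay and not at a number, so the step between them cannot be read and both new steps give only a minimum size: the limit of > 2 h in this assay, at which 2 of the 3 values shown sit.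

The compounds shown cannot separate the effect of bringing in the pyridin-3-yl ring from that of losing the 5-methylthiophen-2-yl ring, and they give no cause for the lower number. A plain phenyl, an unsubstituted thiophen-2-yl or a pyridin-4-yl at this place would help to show which feature of the change goes with the shorter half-life.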